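The compounds below may be only part of what the source reports. "The series", "measured", "known", "first", "only" and "open" are said of these compounds alone.

Compound 1 `Cc1ccc2c(Cc3nn4cc(-c5ccc(Cl)cc5)nc4s3)coc2c1` and compound 2 `Cc1ccc2c(Cc3nn4c(CO)c(-c5ccc(Cl)cc5)nc4s3)coc2c1` share one core and were both tested in a functional assay on the whole organism (strain Wistar albino) for inhibition, with Rattus norvegicus as the target, read by paw edema, with a stated time of 2 h, at a dose of 100 mg/kg by the oral route; a lower number here means less inhibition, a higher number more inhibition at the dose given (going by the name of the read-out). In that assay compound 1 gives 42.1%, while compound 2 gives 28.9%. Within the data shown here, the only step between them, a number 13.2 percentage points lower from compound 1 to compound 2 (beyond the scatter), is the sole comparison available, so compound 2 stands at the lower of the two numbers, with compound 1 beyond the scatter above it.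

Compound 3 `Cc1ccc2c(Cc3nn4c(/C=N/O)c(-c5ccc(Cl)cc5)nc4s3)coc2c1` differs from compound 2 by a group of 3 heavy atoms (1 carbon, 1 nitrogen, 1 oxygen; no ring) in place of a group of 2 heavy atoms (1 carbon, 1 oxygen; no ring), on an aromatic carbon. Among the measured compounds shown here, no measured step swaps one of these two groups for the other; the step from compound 1 to compound 2 concerns only the arrival of the hydroxymethyl group and so bears on the present change only indirectly. With nothing showing that the group which enters behaves differently from the one it replaces, compound 3 is expected to give about 30%, in the range 18% to 43%. The step this estimate implies, a number 1.1 percentage points higher from compound 2 to compound 3 (within the scatter), is expected to stay within the scatter.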

Compound 3, a percentage reported as inhibition, in the whole organism at one dose (the size of the read-out at that dose, not a potency): 11.2%
Compound 3: middle estimate off by 18.8 percentage points, on the high side; measured number below the stated range.
By their numbers in this assay, from the lowest: compound 3; then compound 2; then compound 1.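

The position is not indifferent to which group it carries. In this assay, the three-heavy-atom group with a double bond outside the ring gives a number 17.7 percentage points lower from compound 2 to compound 3 (beyond the scatter), so the two substituents, each on the aromatic carbon next to the ring nitrogen, are told apart by this read-out. Set against the hydrogen of the shared core, the same group gives a number 30.9 percentage points lower from compound 1 to compound 3 (beyond the scatter), which makes compound 3 the lowest of the three, and both groups at this position lie below compound 1; nothing available accounts for this fall.

The compounds shown leave open whether any group at this position can match the hydrogen of compound 1. On these data alone, it also remains open where an amine, a carboxylic acid or a longer chain here would fall relative to compound 2 and compound 3.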